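The source may hold more compounds than are shown below. What is called first, only, known or untested is meant among the compounds shown, and "the series" means these compounds.

The measured compounds are compound 1 `CCN(C1=NCCN1)c1c(Br)cccc1Br` with 11.1, compound 2 `CC(C)CCN(C1=NCCN1)c1c(Br)cccc1Br` with 10.9, and compound 3 `Brc1cccc(Br)c1N(Cc1ccccc1)C1=NCCN1` with 10.4.

In a physicochemical assay for acid dissociation, compound 1 stands highest of the three numbers: compound 2 sits a number 0.20 log units lower from compound 1 to compound 2 (within the scatter), and compound 3 sits a number 0.70 log units lower from compound 1 to compound 3 (beyond the scatter). Compound 4 `Brc1cccc(Br)c1N(Cc1cccs1)C1=NCCN1` differs from compound 1 in one place: thiophen-2-yl in place of methyl on a saturated chain carbon bound to a nitrogen on an aromatic ring. The step that bears most directly on this change is the one in which phenyl replaced methyl at the same place, a number 0.70 log units lower from compound 1 to compound 3 (beyond the scatter); the related step of a number 0.50 log units lower from compound 2 to compound 3 (beyond the scatter) points the same way. A downward step of about that size is therefore expected for compound 4, estimated as a number 0.70 log units lower from compound 1 to compound 4 (beyond the scatter). Compound 4 is expected to give 10.4, in a range from 10 to 10.8.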

Compound 4, acid dissociation constant: 10.5
Compound 4: the middle estimate sits 0.10 log units below what was measured, within the range that was stated.
By their numbers in this assay, from the lowest: compounds 3 and 4 (each within the scatter of the next); then compounds 2 and 1 (each within the scatter of the next).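

In this assay, thiophen-2-yl on this saturated chain carbon reads the same as phenyl, a number 0.10 log units higher from compound 3 to compound 4 (within the scatter), so the two aromatic rings cannot be told apart here. The downward step from methyl thus holds for a five-membered aromatic ring with a sulfur atom as well, a number 0.60 log units lower from compound 1 to compound 4 (beyond the scatter), and the step from isobutyl does too, a number 0.40 log units lower from compound 2 to compound 4 (beyond the scatter). Nothing measured here gives a reason for these steps.

The compounds shown leave open whether thiophen-3-yl, a pyridine ring or a phenyl ring carrying an amine would fall at the same level, and whether a longer chain between this carbon and the ring would keep the step.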